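Replacing the sulfonamide arm with a pentylphenyl group

The compounds below may be only part of what the source reports. "The series", "measured", "known", "first", "only" and "open" are said of these compounds alone.

Compound 2 `O=C1O[C@H]([C@@H](O)Cn2cc(CNS(=O)(=O)c3ccc(F)cc3)nn2)C(OCc2ccccc2)=C1OCc1ccccc1` gives 34700 nM in a functional assay on CFPAC-1 cells (Homo sapiens) for antiproliferative activity, read by MTT assay, with a stated time of 72 h (on this read-out lower numbers stand for stronger inhibition and higher numbers for weaker inhibition), the lowest of the two numbers seen, while compound 1 `O=C1O[C@H]([C@@H](O)Cn2cc(CNS(=O)(=O)c3ccc(Cl)cc3F)nn2)C(OCc2ccccc2)=C1OCc1ccccc1` gives 58200 nM; the step of a 1.7-fold lower number from compound 1 to compound 2 (0.22 log units; within the scatter) lies within the scatter. Compound 3 `CCCCCc1ccc(-c2cn(C[C@H](O)[C@H]3OC(=O)C(OCc4ccccc4)=C3OCc3ccccc3)nn2)cc1` differs from compound 2 in one place: 4-pentylphenyl in place of (((4-fluorophenyl)sulfonyl)amino)methyl on an aromatic carbon. For the measured compounds named here, the only measured step swaps one aryl on the sulfonyl sulfur for another and does not bear on removing the whole sulfonamide arm, so no direction can be read from it. Compound 3 is therefore expected to give about 30000 nM in this assay, between 8000 nM and 120000 nM, a step of a 1.2-fold lower number from compound 2 to compound 3 (0.06 log units; within the scatter) that is expected to stay within the scatter.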

Compound 3, half-maximal inhibitory concentration: 9890 nM
Compound 3: middle estimate off by 3.0-fold (0.48 log units), on the high side; measured number inside the range.
By their numbers in this assay, from the lowest: compound 3; then compounds 2 and 1 (each within the scatter of the next).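

At this aromatic carbon, the whole arm can be exchanged with a measurable result in this assay: 4-pentylphenyl in place of (((4-fluorophenyl)sulfonyl)amino)methyl gives a 3.5-fold lower number from compound 2 to compound 3 (0.55 log units; beyond the scatter), a modest step beyond the scatter, whereas the earlier aryl swap on the sulfonyl sulfur stayed within it. The entering group has no hydrogen-bond donors or acceptors, and compound 3 still inhibits more strongly than compound 2. Nothing available explains this step. Going by these compounds, it remains open whether the phenyl ring or the pentyl chain carries the gain; a bare phenyl, a shorter ethyl chain or a terminal amine on the chain would separate them.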